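Swapping methyl for chloro on a shared core

The compounds below may be only part of what the source reports. "The series", "measured", "known", "first", "only" and "open" are said of these compounds alone.

Of the compounds shown here, three built on one core have been measured in a functional assay on cells for agonist activity at Free fatty acid receptor 1 (Homo sapiens), read by FLIPR and calcium flux, with a stated time of 100 s; a lower number here means that less compound is needed, a higher number that more compound is needed for the effect. Compound 1 `Cc1cccc(Oc2ccc(N3CCC[C@H]3CC(=O)O)cc2)c1` gives 260 nM, compound 2 `O=C(O)C[C@@H]1CCCN1c1ccc(Oc2cccc(Cl)c2)cc1` gives 680 nM, and compound 3 `Cc1ccc(Oc2ccc(N3CCC[C@H]3CC(=O)O)cc2)cc1` gives 490 nM. Compound 1 and compound 3 hold the same atoms joined differently; their difference is 4-methylphenyl in place of 3-methylphenyl on an oxygen on an aromatic ring. The step between them is a 1.9-fold higher number from compound 1 to compound 3 (0.28 log units; within the scatter), and between compound 2 and compound 3 it is a 1.4-fold lower number from compound 2 to compound 3 (0.14 log units; within the scatter), so neither pair can be ordered. For the measured compounds named here, the one change that passes the scatter is chloro in place of methyl on an aromatic carbon, which produced a 2.6-fold higher number from compound 1 to compound 2 (0.42 log units; beyond the scatter).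

Compound 4 `O=C(O)C[C@@H]1CCCN1c1ccc(Oc2ccc(Cl)cc2)cc1` has not yet been measured. It differs from compound 3 by chloro in place of methyl on an aromatic carbon. This is the same kind of change as that from compound 1 to compound 2, but not the same: there the group sits meta to a large group, here it sits para to a large group. Going by the values given here, only one earlier example exists, and it is on the other position, so the expectation rests on that single step. Compound 4 is expected to give 1000 nM. Compound 4 is expected to fall between 400 nM and 2500 nM. The expected step is a 2.0-fold higher number from compound 3 to compound 4 (0.31 log units; beyond the scatter), which rests on the earlier exchange because it gave a 2.6-fold higher number from compound 1 to compound 2 (0.42 log units; beyond the scatter), softened slightly since the position is not the same.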

Compound 4, half-maximal effective concentration: 290 nM
Estimate against measurement, compound 4: 3.4-fold (0.54 log units) above; measured number below the stated range.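

In this assay, chloro in place of methyl, here as 4-methylphenyl to 4-chlorophenyl, gives a 1.7-fold lower number from compound 3 to compound 4 (0.23 log units; within the scatter), a step that leaves the two compounds unordered, so the change did not carry over from one core to the other with the size it had before, and the two exchanges differ: the same change on two cores in this assay, a 2.6-fold higher number (0.42 log units; beyond the scatter) from compound 1 to compound 2 and a 1.7-fold lower number (0.23 log units; within the scatter) from compound 3 to compound 4, 4.4-fold (0.65 log units) apart, beyond the scatter of two such steps The same pair of groups therefore cannot be treated as a fixed increment in this series, since what it does on one aromatic position says little about what it does on the other; moving the chloro does register, with a 2.3-fold lower number from compound 2 to compound 4 (0.37 log units; beyond the scatter), a modest step, while a 1.1-fold higher number from compound 1 to compound 4 (0.05 log units; within the scatter) leaves those two compounds unordered. This rests on one pair for each position, so it shows that the exchange failed to transfer here but gives no reason for that and no rule for other members of the series.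

The compounds shown leave open how a fluoro, a methoxy or a nitrile would behave on the same aromatic carbon, and whether any of them would follow compound 2 or compound 4. They also leave open whether the difference between the two exchanges would survive with an amide or a longer chain in place of the carboxylic acid.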